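Extending a Chain in a Series That Stays Unmeasurable

A few compounds are considered here, and "the series" means these few. Any claim that something is new, unique, unknown or untested is made for them only; others in the source may bear on it.

The measured compounds, each read only as a limit:
Compound 1 `Cc1nnc(SCC(=O)c2ccc(Cl)cc2)n1N1C(=O)c2ccccc2C1=O`: in a functional assay on A549 cells (Homo sapiens) for cytotoxicity, read by MTT assay, with a stated time of 48 h (a lower number here means a stronger inhibitor, a higher number a weaker inhibitor), compound 1 gives > 200000 nM, which is a limit of the assay and not a number.
Compound 2 `C=CCSc1nnc(CC)n1N1C(=O)c2ccccc2C1=O`: in this assay compound 2 gives > 200000 nM, again a limit.
Compound 3 `C=CCSc1nnc(CCC)n1N1C(=O)c2ccccc2C1=O`: in this assay compound 3 gives > 200000 nM, again a limit.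

Compound 3 therefore stands at the upper limit of this assay, and the two other values shown sit at the same limit. Going by the values given here, the single step between measured compounds, a step that the two limits leave unreadable from compound 2 to compound 3, cannot be read because of the limit of > 200000 nM in this assay, at which 3 of the 3 values shown sit, so no sized step is available at all.

Compound 4 `CCCc1nnc(SCC(=O)c2ccc(Cl)cc2)n1N1C(=O)c2ccccc2C1=O` differs from compound 3 by (4-chlorophenyl)carbonyl in place of vinyl on a saturated chain carbon bound to a sulfur. Among the compounds with values here, no measured pair follows this same change. What can be said is that compound 1 already carries the same (4-chlorophenyl)carbonyl-bearing side chain on the shared core and sits at the limit, and compound 3 with the propyl sits at the limit too. The expectation is therefore no step beyond the scatter, with the number most likely again reported only as a limit.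

Compound 4 is expected to give about 300000 nM, within 100000 nM to 1000000 nM. That corresponds to an expected step that the limit leaves unreadable from compound 3 to compound 4.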

Compound 4, half-maximal inhibitory concentration: > 200000 nM
Compound 4 was reported as a limit; the forecaster's own chance of this, stated with the estimate: 85%; the middle value does not contradict the limit.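

Compound 4 adds no readable step, neither from compound 3 nor from compound 1, because all of these compounds give the same limit and not a number: the limit of > 200000 nM in this assay, at which 4 of the 4 values shown sit.

The compounds shown leave open whether any change of the chain or side chain on the shared core can bring a measurable value in this assay at all.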